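This account rests on a few compounds, and the source may have more. Where it says the series, first, only, none or still open, it means among the compounds named here.

Measured compounds:
Compound 1, `COC(=O)[C@@]1(C)CC[C@@H]2C3=C1CC[C@@H](C)[C@]3(C)C[C@@H]1c3ccccc3N[C@H]21`, gives 39000 nM.
Compound 2, `COC(=O)[C@@]1(C)CC[C@@H]2C3=C1CC[C@@H](C)[C@]3(C)Cc1c2[nH]c2ccccc12`, gives 4600 nM.
Compound 3, `COC(=O)[C@@]1(C)CC[C@@H]2C3=C1CC[C@@H](C)[C@]3(C)Cc1c2[nH]c2ccc(C)cc12`, gives 16000 nM.

All three were tested in a functional assay on A549 cells (Homo sapiens) for inhibition, read by sulforhodamine B assay, with a stated time of 48 h; a higher number here means a weaker inhibitor of growth, a lower number a stronger inhibitor of growth. Compound 2 has the lowest of the three numbers; compound 1 the highest. Compound 1 and compound 2 are built on different cores, and the difference between the two cores is not broken down here. Between compound 2 and compound 3 one change is made, (methyl in place of hydrogen on an aromatic carbon), and it gives a 3.5-fold higher number from compound 2 to compound 3 (0.54 log units; beyond the scatter).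

The unmeasured compound 4, `COC(=O)[C@@]1(C)CC[C@@H]2C3=C1CC[C@@H](C)[C@]3(C)C[C@@H]1c3cccc(C)c3N[C@H]21`, is reached from compound 1 by methyl in place of hydrogen on an aromatic carbon. Going by the values given here, this is the same kind of change as the one from compound 2 to compound 3, but the place differs: in compound 4 the methyl sits ortho to a fused ring and meta to a fused ring, whereas in compound 3 it sits meta to a fused ring and para to a fused ring. The step from compound 1 to compound 4 in this assay is expected to be a 2.1-fold higher number from compound 1 to compound 4 (0.31 log units; beyond the scatter), a guess resting on the step from compound 2 to compound 3, a 3.5-fold higher number from compound 2 to compound 3 (0.54 log units; beyond the scatter), applied to a different core and a different place. Compound 4 is therefore estimated at 80000 nM, plausibly between 25000 nM and 250000 nM.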

Compound 4, concentration for 50% growth inhibition: 30000 nM
Estimate against measurement, compound 4: 2.7-fold (0.43 log units) above; the measured number falls inside the stated range.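

In this assay, putting methyl in place of hydrogen on an aromatic carbon gives a 1.3-fold lower number from compound 1 to compound 4 (0.11 log units; within the scatter), so on this core the change makes no clear difference. The same change therefore does not carry over with the same result from one core to the other: the same change on two cores in this assay, a 3.5-fold higher number (0.54 log units; beyond the scatter) from compound 2 to compound 3 and a 1.3-fold lower number (0.11 log units; within the scatter) from compound 1 to compound 4, 4.5-fold (0.66 log units) apart, beyond the scatter of two such steps. What is not shown is whether the core or the place of the methyl accounts for this gap, as the two differ together, and two steps make no rule for the series.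

The compounds shown leave open what methyl does at one and the same place on both cores. They also leave open what other groups, such as chlorine, methoxy or an amine, would do there.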